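The source may hold more compounds than are shown below. What is called first, only, known or untested is meant among the compounds shown, and "the series" means these compounds.

Measured so far:
Compound 1, `C=CCOC(=O)Nc1ccc([Se]C#N)cc1`: 48600 nM
Compound 2, `Cc1ccc(OC(=O)Nc2ccc([Se][Se]c3ccc(NC(=O)Oc4ccc(C)cc4)cc3)cc2)cc1`: 39400 nM

Both numbers come from a functional assay on HT-29 cells (Homo sapiens) for cytotoxicity, read by MTT assay, with a stated time of 72 h; a lower number here means a stronger inhibitor of growth, a higher number a weaker inhibitor of growth. Compound 1 has the higher of the two numbers, but its gap to compound 2 lies within the scatter, so the two read as alike in this assay. Compound 3, `CCCCCCOC(=O)Nc1ccc([Se]C#N)cc1`, has not yet been measured. It differs from compound 1 in one place: pentyl in place of vinyl on a saturated chain carbon bound to an oxygen next to a carbonyl group. Among the measured compounds shown here, no measured pair shows what this change does, so the expectation rests on compound 1 alone, and the step in this assay is expected to be small, likely within the scatter. Compound 3 is expected to give 35000 nM, with a range from 12000 nM to 100000 nM. The expected step is a 1.4-fold lower number from compound 1 to compound 3 (0.14 log units; within the scatter).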

Compound 3, concentration for total growth inhibition: 40300 nM
For compound 3 the middle estimate is 1.2-fold (0.06 log units) below the measured one; the measured number falls inside the stated range.
By their numbers in this assay, from the lowest: compounds 2, 3 and 1 (each within the scatter of the next).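

Compound 3 carries pentyl where compound 1 has vinyl on a saturated chain carbon bound to an oxygen next to a carbonyl group, and in this assay the step is a 1.2-fold lower number from compound 1 to compound 3 (0.08 log units; within the scatter) for this change. At this position, then, a saturated chain with more carbons and no double bond reads alike to the vinyl compound, though this single pair cannot separate chain length from loss of the double bond. Nothing measured here explains this result. Going by these compounds, whether an amine or a carboxylic acid at this position would behave the same stays open. So does whether a phenyl ring there would give a step beyond the scatter.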